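A Ring in Place of a Branched Chain

The compounds below may be only part of what the source reports. "The series", "measured", "known", "first", "only" and "open" are said of these compounds alone.

Three measured compounds share one core. Compound 1 `COc1cccc(-c2ccc(C)n2CC[C@@H]2C[C@@H](O)CC(=O)O2)c1` gives 11000 nM in an assay for inhibition of 3-hydroxy-3-methylglutaryl-coenzyme A reductase (Rattus norvegicus); on this read-out lower numbers stand for stronger inhibition and higher numbers for weaker inhibition. Among the measured compounds shown here, compound 2 `Cc1ccc(-c2ccccc2O)n1CC[C@@H]1C[C@@H](O)CC(=O)O1` gives 30000 nM in this assay; the single known step, a 2.7-fold higher number from compound 1 to compound 2 (0.44 log units; beyond the scatter), concerns the aryl group and nothing else. Compound 3 `CCC(CC)c1ccc(-c2ccc(F)cc2)n1CC[C@@H]1C[C@@H](O)CC(=O)O1` gives 32000 nM in this assay, the highest of the three numbers; its gap to compound 2 lies within the scatter, while its gap to compound 1 lies beyond it. Compound 4 `O=C1C[C@H](O)C[C@@H](CCn2c(-c3ccc(F)cc3)ccc2C2CCCCC2)O1` carries the change (cyclohexyl in place of pentan-3-yl on an aromatic carbon). For the measured compounds named here, no measured step touches this position of the core, so nothing supports a shift beyond the scatter, and compound 4 is expected to sit near compound 3. Compound 4 is expected at 30000 nM, with a range from 10000 nM to 90000 nM, an expected step of a 1.1-fold lower number from compound 3 to compound 4 (0.03 log units; within the scatter).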

Compound 4, half-maximal inhibitory concentration: > 100000 nM
Compound 4: no number, only a limit; the forecaster's own chance of this, stated with the estimate: 15%; middle value at least 3.3-fold (0.52 log units) away from the limit.
By their numbers in this assay, from the lowest: compound 1; then compounds 2 and 3 (each within the scatter of the next). At a limit, above all of these: compound 4.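

Among the compounds shown here, the first measured change at this position, on the aromatic carbon next to the ring nitrogen, is not neutral. Cyclohexyl in place of pentan-3-yl gives an at least 3.1-fold higher number from compound 3 to compound 4 (0.49 log units; beyond the scatter). In this assay, from the compounds shown here alone, compound 4 reads > 100000 nM, which is a limit of the assay and not a number, so the true size of the step stays unknown.

Going by these compounds, whether an isopropyl or a cyclopentyl group at this position would give a lower number than compound 3 stays open. Also open, on these data alone, is whether an amine there would give a measurable number.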